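This account rests on a few compounds, and the source may have more. Where it says the series, first, only, none or still open, it means among the compounds named here.

The three measured compounds, compound 1 `COc1cc(NC(=O)Nc2cc(Nc3ccc(OC)c(C)c3)ncn2)cc(OC)c1`, compound 2 `COc1cc(NC(=O)Nc2cc(Nc3cccc(C(C)(C)C)c3)ncn2)cc(OC)c1` and compound 3 `COc1cc(NC(=O)Nc2cc(Nc3ccc(F)c(Cl)c3)ncn2)cc(OC)c1`, share one core and differ only in the group on a nitrogen on an aromatic ring. In a functional assay on NCI-H520 cells (Homo sapiens) for inhibition, read by MTT assay, with a stated time of 48 h, tested at 10 uM (a higher number here means more inhibition at the concentration tested (going by the name of the read-out), a lower number less inhibition), compound 1 gives 13.5%, compound 2 gives 13.1% and compound 3 gives 25.5%. Compound 3 holds the highest of the three numbers: the step of a number 12 percentage points higher from compound 1 to compound 3 (beyond the scatter) and the step of a number 12.4 percentage points higher from compound 2 to compound 3 (beyond the scatter) are both beyond the scatter, while the step of a number 0.4 percentage points lower from compound 1 to compound 2 (within the scatter) is within it.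

Compound 4 `COc1cc(NC(=O)Nc2cc(Nc3ccc(C)c(C)c3)ncn2)cc(OC)c1` is still to be measured in this assay. Its change from compound 3 is 3,4-dimethylphenyl in place of 3-chloro-4-fluorophenyl on a nitrogen on an aromatic ring. The two steps that bear on it both ran toward compound 3 from groups without chlorine or fluorine and were modest gains; the group entering in compound 4 again carries neither chlorine nor fluorine, so a step of similar size is expected in the opposite direction, back toward the numbers of compounds 1 and 2. The expected step is a number 10.5 percentage points lower from compound 3 to compound 4 (beyond the scatter). For compound 4 the estimate is 15%, within 5% to 27%.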

Compound 4, a percentage reported as inhibition, at one concentration (the size of the read-out at that concentration, not a potency): 29.5%
Compound 4: middle estimate off by 14.5 percentage points, on the low side; the measured number lies above the stated range.
By their numbers in this assay, from the lowest: compounds 2 and 1 (each within the scatter of the next); then compounds 3 and 4 (each within the scatter of the next).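

In this assay the change reads a number 4 percentage points higher from compound 3 to compound 4 (within the scatter) and so shows that chlorine and fluorine are not required for the higher numbers at this position, since 3,4-dimethylphenyl and 3-chloro-4-fluorophenyl cannot be told apart here. The contrast within the non-halogen groups is larger: the step of a number 16 percentage points higher from compound 1 to compound 4 (beyond the scatter) comes from methyl in place of methoxy on an aromatic carbon alone, and the step of a number 16.4 percentage points higher from compound 2 to compound 4 (beyond the scatter) separates 3,4-dimethylphenyl from 3-(tert-butyl)phenyl as well. Nothing available gives a reason for these steps.

Open, going by these compounds, is whether a single methyl on the phenyl ring keeps the number of the 3,4-dimethylphenyl group. Also open, on these data alone, is how an amine or a carboxylic acid on that ring would read.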